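Methylating the Amide Nitrogen on a Second Side Chain

The source may hold more compounds than are shown below. What is called first, only, known or untested is meant among the compounds shown, and "the series" means these compounds.

Measured so far:
Compound 1 `CCCNC(=O)Cn1c(-c2ccc(Cl)cc2)nc2cccnc21` gives 37.5 mg/kg in a functional assay on the whole organism with Mus musculus as the target; a higher number here means that more compound is needed for the effect, a lower number that less compound is needed.
Compound 2 `CCCN(C)C(=O)Cn1c(-c2ccc(Cl)cc2)nc2cccnc21` gives 11.6 mg/kg in this assay.
Compound 3 `CN(C)CCNC(=O)Cn1c(-c2ccc(Cl)cc2)nc2cccnc21` gives 62 mg/kg in this assay.

Compound 3 differs from compound 1 only in dimethylamino in place of methyl on a saturated chain carbon, two bonds along the chain from an amide-type nitrogen, and that step, a 1.7-fold higher number from compound 1 to compound 3 (0.22 log units; within the scatter), is within the scatter, so the two side chains give no distinguishable outcome. The step of a 5.3-fold higher number from compound 2 to compound 3 (0.73 log units; beyond the scatter), however, is beyond the scatter.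

Compound 4 `CN(C)CCN(C)C(=O)Cn1c(-c2ccc(Cl)cc2)nc2cccnc21` is not yet measured. It differs from compound 3 in methyl in place of hydrogen on an amide-type nitrogen. The same change, (methyl in place of hydrogen on an amide-type nitrogen), has one precedent: from compound 1 to compound 2 it gave a 3.2-fold lower number from compound 1 to compound 2 (0.51 log units; beyond the scatter). The place is the same word for word in both cases; only the chain carried by that nitrogen differs, as told above.

If the change carries over, compound 4 is expected to show a step of about a 3.1-fold lower number from compound 3 to compound 4 (0.49 log units; beyond the scatter), a view resting on the single earlier step of a 3.2-fold lower number from compound 1 to compound 2 (0.51 log units; beyond the scatter). Compound 4 is therefore estimated at 20 mg/kg, most likely between 8 mg/kg and 45 mg/kg.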

Compound 4, dose for half-maximal effect: 100 mg/kg
For compound 4 the middle estimate is 5.0-fold (0.70 log units) below the measured one; measured number outside the range, above it.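

In this assay, methyl in place of hydrogen on the amide-type nitrogen gives a 1.6-fold higher number from compound 3 to compound 4 (0.21 log units; within the scatter), a step within the scatter that does not repeat the drop seen on the propyl chain: the same change on two cores in this assay, a 3.2-fold lower number (0.51 log units; beyond the scatter) from compound 1 to compound 2 and a 1.6-fold higher number (0.21 log units; within the scatter) from compound 3 to compound 4, 5.2-fold (0.72 log units) apart, beyond the scatter of two such steps. The same dependence appears from the other side, since dimethylamino in place of methyl gives an 8.6-fold higher number from compound 2 to compound 4 (0.94 log units; beyond the scatter) when the amide-type nitrogen carries a methyl, whereas the matching step without that methyl stays within the scatter: the same change on two cores in this assay, a 1.7-fold higher number (0.22 log units; within the scatter) from compound 1 to compound 3 and an 8.6-fold higher number (0.94 log units; beyond the scatter) from compound 2 to compound 4, 5.2-fold (0.72 log units) apart, beyond the scatter of two such steps. Together with a 2.7-fold higher number from compound 1 to compound 4 (0.43 log units; beyond the scatter), where the whole side chain changes in one step, this shows that the methyl cannot be carried from one side chain to the other as a fixed shift, but it does not show why the outcomes differ, and two pairs give no rule for other chains.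

Still open, as far as these compounds go, is how the same methyl step behaves on a longer chain ending in dimethylamino. A chain ending in a carboxylic acid is equally untested among the compounds shown here.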